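This account rests on a few compounds, and the source may have more. Where it says the series, first, only, none or still open, it means among the compounds named here.

Compound 1 `Cc1c(OCCCCOc2ccc(C(=O)O)cc2)ccc(C(=O)CC2CCCC2)c1O`: 824 nM
Compound 2 `Cc1cc(C(=O)O)ccc1OCCCCOc1ccc(C(=O)CC(C)C)c(O)c1C`: 192 nM

In an assay on HEK293 cells for positive allosteric modulation of metabotropic glutamate receptor 2 (Rattus norvegicus), read by thallium flux, with a stated time of 2.5 min (on this read-out lower numbers stand for an effect already at smaller amounts and higher numbers for an effect only at larger amounts of compound), compound 1 gives 824 nM, the higher of the two numbers measured. Compound 2 gives 192 nM, and the gap between the two lies beyond the usual scatter. Compound 3 `COc1ccc(C(=O)O)cc1OCCCCOc1ccc(C(=O)CC2CCCC2)c(O)c1C` has not yet been measured. It differs from compound 1 in one place: 5-carboxy-2-methoxyphenyl in place of 4-carboxyphenyl on an oxygen on a saturated carbon. Going by the values given here, no measured pair shows this kind of change, so nothing here tells how large its effect is. The step of a 1.2-fold lower number from compound 1 to compound 3 (0.07 log units; within the scatter) is expected to stay within the usual scatter, in no clear direction. Compound 3 is therefore expected to give about 700 nM, somewhere between 250 nM and 2000 nM.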

Compound 3, half-maximal effective concentration: 425 nM
The estimate for compound 3 lay 1.6-fold (0.22 log units) above the measured number; low and high end bracket the measured number.
By their numbers in this assay, from the lowest: compound 2; then compounds 3 and 1 (each within the scatter of the next).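

In this assay, the ring on an oxygen on a saturated carbon accepts a larger group: 5-carboxy-2-methoxyphenyl in place of 4-carboxyphenyl gives a 1.9-fold lower number from compound 1 to compound 3 (0.29 log units; within the scatter), so the added methoxy and the changed carboxy numbering together leave the number within the scatter. No measurement on hand explains this tolerance. From the compounds shown here alone, the step combines both differences, so their separate contributions remain unknown, and they could even offset each other. Going by these compounds, it is also open whether a larger ethoxy group in place of the methoxy would be tolerated equally well.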